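Changing the Amide Substituent in a Kinase Series

The compounds below may be only part of what the source reports. "The series", "measured", "known", "first", "only" and "open" are said of these compounds alone.

In an assay on isolated protein for inhibition of Rho-associated protein kinase 2 (Homo sapiens), read by HTRF, tested at 10 uM (a lower number here means less inhibition, a higher number more inhibition at the concentration tested (going by the name of the read-out)), the three measured compounds give:
Compound 1 `COC[C@@H]1CCCN1C(=O)[C@@H]1CCCN1c1cc(Nc2cccc(OC)c2)nc(N)n1`: 0%
Compound 2 `Cc1cccc(Oc2ccnc(N3CCC[C@H]3C(=O)NCCCn3ccnc3)n2)c1`: 0%
Compound 3 `CN(CCCn1ccnc1)C(=O)[C@@H]1CCCN1c1nccc(Nc2ccccc2)n1`: 1%

Compound 2 stands level with compound 1 at the digits shown, and together they are the lowest of the three numbers; compound 3 lies one point higher, which is within the scatter, so no order among the three can be read from these values. All three sit at the floor of this assay.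

Compound 4 `COC(=O)C(CO)NC(=O)[C@@H]1CCCN1c1nccc(Oc2cccc(C)c2)n1` differs from compound 2 in one place: 2-hydroxy-1-(methoxycarbonyl)ethyl in place of 3-(1H-imidazol-1-yl)propyl on an amide-type nitrogen. Going by the values given here, no pair of measured compounds differing in one place is available to size such a change, so the expectation rests only on the flat numbers of compounds 1, 2 and 3. The step from compound 2 to compound 4 is expected to be a number 2 percentage points higher from compound 2 to compound 4 (within the scatter), that is, none beyond the scatter. Compound 4 is therefore estimated at 2%, with a range from -8% to 12%.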

Compound 4, a percentage reported as inhibition, at one concentration (the size of the read-out at that concentration, not a potency): 0%
Compound 4: middle estimate off by 2 percentage points, on the high side, and the stated range covers the measured number.
By their numbers in this assay, from the lowest: compounds 1, 2, 4 and 3 (each within the scatter of the next).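

In this assay, going by these compounds alone, putting 2-hydroxy-1-(methoxycarbonyl)ethyl in place of 3-(1H-imidazol-1-yl)propyl on the amide-type nitrogen gives no change at the digits printed from compound 2 to compound 4 (within the scatter) and so provides the first comparison of compounds differing in one place. A five-membered aromatic ring leaves and a group with no ring enters, yet both compounds stay at the floor of the assay, so this step cannot show how much the position matters. No measurement at hand bears on why the number stays flat. Going by these compounds, whether a primary amine or a carboxylic acid on this nitrogen would give a number above the floor remains open. So does whether a longer chain would.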